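Swapping a cyclobutyl amide for a 4-chlorophenyl amide

The source may hold more compounds than are shown below. What is called first, only, known or untested is meant among the compounds shown, and "the series" means these compounds.

Measured so far:
compound 1, `CN1CCC(C(=O)N2Cc3c(NC(=O)C4CCC4)n[nH]c3C2(C)C)CC1`: 140 nM
compound 2, `CN1CCC(C(=O)Nc2n[nH]c3c2CN(C(=O)C(C)(C)C)C3(C)C)CC1`: 350 nM

Both compounds share one core and were tested in a functional assay on A2780 cells (Homo sapiens) for antiproliferative activity, read by fluorescence, with a stated time of 72 h; a higher number here means a weaker inhibitor, a lower number a stronger inhibitor. Compound 1 gives the lower of the two numbers, 140 nM, and compound 2 sits higher at 350 nM, a gap beyond the usual scatter, so compound 1 is the stronger of the pair. The two differ in more than one place, so no single change can be read from that gap.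

Compound 3, `CN1CCC(C(=O)N2Cc3c(NC(=O)c4ccc(Cl)cc4)n[nH]c3C2(C)C)CC1`, has not yet been measured. It differs from compound 1 in one place: 4-chlorophenyl in place of cyclobutyl on a carbonyl carbon. Within the data shown here, no measured pair isolates this change, so the expectation rests only on compound 1 and the usual behaviour of such amide swaps. Compound 3 is expected to land close to compound 1, with the step of a 1.4-fold lower number from compound 1 to compound 3 (0.15 log units; within the scatter) estimated as small and possibly slightly favourable, within or just beyond the scatter. The estimate for compound 3 in this assay is 100 nM, with a range from 30 nM to 400 nM.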

Compound 3, half-maximal inhibitory concentration: 120 nM
Beside the measured number, compound 3's estimate is 1.2-fold (0.08 log units) below it; low and high end bracket the measured number.
By their numbers in this assay, from the lowest: compounds 3 and 1 (each within the scatter of the next); then compound 2.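

Among these compounds, this is the first pair here that differs in one place only, so the group on this carbonyl carbon can now be read on its own: in this assay the change from cyclobutyl to 4-chlorophenyl gives a 1.2-fold lower number from compound 1 to compound 3 (0.07 log units; within the scatter) and leaves the number within the scatter. This position therefore holds either a four-membered non-aromatic ring or a larger six-membered aromatic ring bearing chlorine, with no difference that this assay can resolve. No measurement shown explains why the two groups read alike.

The compounds shown leave open what a plain phenyl without the chlorine, an amine, a carboxylic acid or a longer alkyl chain would do on this carbonyl carbon. Steps involving compound 2 cannot be read, as it differs from the other compounds in more than one place.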